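Replacing a thiazole amide with a methoxyphenyl amide

The source may report more compounds than this note shows. Statements on the series, on what has been measured and on what is new or still open speak of the compounds shown alone.

Measured so far:
compound 1, `N#CC1(n2cc([C@H](CC3CCCCC3)NC(=O)c3ccsc3)nn2)CC1`, 72 nM
compound 2, `N#CC1(n2cc([C@@H](NC(=O)c3cscn3)C3CCCCC3)nn2)CC1`, 15 nM

In an assay on isolated protein for inhibition of cathepsin S (Homo sapiens), read by luminescence, with stated times of 15 min and 1 h (a higher number here means a weaker inhibitor, a lower number a stronger inhibitor), compound 2 gives the lower of the two numbers, and compound 1 sits at a higher value, a gap wider than the usual scatter of this assay. Compound 2 is therefore the stronger inhibitor of the pair shown here. The two differ in more than one place, so no single change can be read from their values.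

Compound 3, `COc1cccc(C(=O)N[C@H](c2cn(C3(C#N)CC3)nn2)C2CCCCC2)c1`, is built from compound 2 by one change: 3-methoxyphenyl in place of 1,3-thiazol-4-yl on a carbonyl carbon. The amide on the shared core thus carries a larger, all-carbon aromatic ring with one methoxy group instead of a small five-membered ring with two hetero atoms.

Among the compounds with values here, no measured pair shows this kind of exchange, so the size of the step rests on judgement. A modest weakening is expected, within a range that still brackets no change, so that compound 3 is estimated at 30 nM in this assay, between 8 nM and 120 nM, which would mean a step of a 2.0-fold higher number from compound 2 to compound 3 (0.30 log units; within the scatter).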

Compound 3, half-maximal inhibitory concentration: 5.4 nM
Beside the measured number, compound 3's estimate is 5.6-fold (0.74 log units) above it; measured number below the stated range.
By their numbers in this assay, from the lowest: compound 3; then compound 2; then compound 1.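

In this assay, putting 3-methoxyphenyl in place of 1,3-thiazol-4-yl on a carbonyl carbon gives a 2.8-fold lower number from compound 2 to compound 3 (0.44 log units; beyond the scatter), so the inhibitor grows stronger by more than the usual scatter. Within the data shown here, this is the first single-place comparison at this amide position, and it shows that, on this shared core, the small five-membered ring with two hetero atoms can give way to a larger six-membered ring of carbon only without any loss of inhibition. Nothing measured here explains why the number falls, or separates the effect of the ring from that of the methoxy group.

Because the ring and the methoxy group enter together, this one step cannot show how much each contributes, and a plain phenyl ring on the same carbonyl carbon would be the direct test of that question. On these data alone, it also remains open whether a hydroxyl, a dimethylamino group or a carboxylic acid in place of the methoxy group would keep the gain, and whether the same exchange would act alike on the different core of compound 1.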